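Removing the Bromo Group from Compound 2

The source may hold more compounds than are shown below. What is called first, only, known or untested is meant among the compounds shown, and "the series" means these compounds.

Compound 1 (`O=C(/C=C/c1ccc(CN2C(=O)/C(=C3\Nc4ccccc4\C3=N/O)c3cccc(Cl)c32)cc1)NO`) at 50 nM
Compound 2 (`O=C(/C=C/c1ccc(CN2C(=O)/C(=C3\Nc4ccccc4\C3=N/O)c3cc(Br)ccc32)cc1)NO`) at 9 nM

In a functional assay on NCI-H23 cells (Homo sapiens) for cytotoxicity, read by colorimetric assay (on this read-out higher numbers stand for weaker inhibition and lower numbers for stronger inhibition), compound 2 gives 9 nM and holds the lower of the two numbers, while compound 1 gives 50 nM and lies above it by more than the scatter. Compound 3 (`O=C(/C=C/c1ccc(CN2C(=O)/C(=C3\Nc4ccccc4\C3=N/O)c3ccccc32)cc1)NO`) differs from compound 2 in one place (hydrogen in place of bromo on an aromatic carbon), with hydrogen in place of bromo on an aromatic carbon. For the measured compounds named here, no measured pair differs in one place only, so the data offer no direct guide to this step. With compound 1 also at 50 nM in the same test, a large loss is not expected. A modest rise in the number is expected (a 2.2-fold higher number from compound 2 to compound 3 (0.35 log units; beyond the scatter)), about the size of the scatter or slightly beyond it. The estimated value for compound 3 is 20 nM within an expected range of 6 nM to 70 nM in this read-out.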

Compound 3, half-maximal inhibitory concentration: 9 nM
Compound 3: the middle estimate sits 2.2-fold (0.35 log units) above what was measured; measured number inside the range.
By their numbers in this assay, from the lowest: compounds 2 and 3 (each within the scatter of the next); then compound 1.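

In this assay, putting hydrogen in place of bromo on this aromatic carbon, para to a fused ring, gives no change at the digits printed from compound 2 to compound 3 (within the scatter) and so shows that the number does not depend on the bromo group at this position. Hydrogen in place of chloro gives a 5.6-fold lower number from compound 1 to compound 3 (0.74 log units; beyond the scatter) and so sets compound 1 apart from the other two, which means that taking away a halogen does not have the same outcome in both cases. No measurement at hand accounts for this difference between the bromo and chloro steps.

On these data alone, whether a group other than bromo can be placed on this carbon without moving the number stays open, for example a methoxy group, an amine or a carboxylic acid. Also open, as far as these compounds go, is how chloro would behave on this same carbon.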